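The compounds below may be only part of what the source reports. "The series", "measured", "known", "first", "only" and "open" are said of these compounds alone.

In a functional assay on A549 cells (Homo sapiens) for cytotoxicity, read by MTT assay, with a stated time of 72 h (a higher number here means a weaker inhibitor, a lower number a stronger inhibitor), compound 1 `C#Cc1cccc(Nc2ncnc3oc(C)c(C(=O)OCC)c23)c1` gives > 1000000 nM, which is a limit and not a number. Compound 2 `Cc1oc2ncnc(Nc3cccc(Cl)c3)c2c1C(=O)NC(C)C` also gives only a limit, > 1000000 nM, so its standing is known only from the limit of > 1000000 nM in this assay, at which 2 of the 3 values shown sit. Compound 3 `Cc1oc2ncnc(Nc3cccc(Br)c3)c2c1C(=O)NCCO` gives a number, 17400 nM, but it differs from compound 2 in more than one place and does not isolate any single change. Compound 4 `Cc1oc2ncnc(Nc3cccc(Cl)c3)c2c1C(=O)O` has hydroxy in place of isopropylamino on a carbonyl carbon. Going by the values given here, no measured pair tests this change. The expected step, an at least 2.0-fold lower number from compound 2 to compound 4 (0.30 log units; that floor lies within the scatter), is small and, if it can be resolved at all, towards a stronger inhibitor. Another limit in this assay is also quite likely. For compound 4, the estimated value is 500000 nM, with an expected range of 50000 nM to 1000000 nM.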

Compound 4, half-maximal inhibitory concentration: 95500 nM
Compound 4: the middle estimate sits 5.2-fold (0.72 log units) above what was measured, within the range that was stated.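

In this assay, going by these compounds alone, hydroxy in place of isopropylamino on the carbonyl carbon gives an at least 10-fold lower number from compound 2 to compound 4 (1.01 log units; beyond the scatter), the first step that isolates a change at this position. It shows that this carbonyl substituent alone, with the rest of compound 2 unchanged, can shift the read-out beyond the scatter. Compound 2 holds only a limit, so the true size of the step stays unknown: the limit of > 1000000 nM in this assay, at which 2 of the 4 values shown sit.

Going by these compounds, whether the step comes from the entering hydroxy or from the loss of isopropylamino stays open. A primary amide or a methyl ester on the same carbonyl carbon would help separate the two.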